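A few compounds are considered here, and "the series" means these few. Any claim that something is new, unique, unknown or untested is made for them only; others in the source may bear on it.

Of the compounds shown here, three built on a shared core have been tested in an assay on HEK293 cells for agonist activity at transient receptor potential cation channel subfamily M member 8 (Homo sapiens), read by fluorescence and calcium flux, with a stated time of 15 min; on this read-out higher numbers stand for an effect only at larger amounts of compound and lower numbers for an effect already at smaller amounts. Compound 1 `CCN(Cc1ccco1)C(=O)COc1ccc(C)cc1` gives 489 nM there, compound 3 `CCN(Cc1cccs1)C(=O)COc1ccc2c(c1)CCCC2` gives 689 nM, and compound 2 `Cc1ccc(OCC(=O)N(Cc2cccs2)c2ccccn2)cc1` gives 200 nM. On these numbers compound 2 stands lowest of the three: its nearest neighbour is compound 1 and its furthest is compound 3, and both gaps lie beyond the usual scatter of repeated measurements, so compound 2 is the most potent of the three in this assay.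

Compound 4 `Cc1ccc(OCC(=O)N(Cc2cccs2)c2c[nH]nc2C)cc1` has not yet been measured. It differs from compound 2 in a single place: 3-methyl-1H-pyrazol-4-yl in place of pyridin-2-yl on an amide-type nitrogen. Going by the values given here, no pair among the measured compounds shows this kind of exchange, so there is no measured step to lean on, and any expectation rests on compound 2 alone, which in this assay gives 200 nM. Because compound 2 gives 200 nM, compound 4 is expected to land not far from it, with a step of a 2.0-fold higher number from compound 2 to compound 4 (0.30 log units; within the scatter) estimated toward a somewhat higher number, of a size that may or may not pass beyond the scatter. The estimate for compound 4 in this assay is 400 nM, with an expected range from 120 nM to 1400 nM.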

Compound 4, half-maximal effective concentration: 0.4 nM
The estimate for compound 4 lay 1000-fold (3.00 log units) above the measured number, and the stated range ends above it.
By their numbers in this assay, from the lowest: compound 4; then compound 2; then compounds 1 and 3 (each within the scatter of the next).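

In this assay, the group on the amide-type nitrogen turns out to have a very large influence: 3-methyl-1H-pyrazol-4-yl in place of pyridin-2-yl gives a 500-fold lower number from compound 2 to compound 4 (2.70 log units; beyond the scatter), even though both groups have the same number of heavy atoms and neither carries a net charge. Going by these compounds alone, the earlier compounds offered no pair differing in one place, so this is the first measured sign of how much the potency can move with a single exchange, here from a six-membered aromatic ring with 1 hetero atom to a five-membered aromatic ring with 2 hetero atoms that also brings a hydrogen-bond donor. No measurement shown here accounts for the size of this step.

Within the data shown here, the single exchange leaves open whether the ring size, the ring nitrogen hydrogen or the methyl group carries the step, and a 1H-pyrazol-4-yl without the methyl or a 1-methylpyrazol-4-yl on the same nitrogen would help to separate these. Also open, as far as these compounds go, is whether the same exchange would hold with a furan-2-ylmethyl group or a tetrahydronaphthalene-type aryl ether elsewhere on the shared core.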